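This account rests on a few compounds, and the source may have more. Where it says the series, first, only, none or still open, it means among the compounds named here.

Measured so far in an in vitro functional assay on HEK285-7 cells for antagonist activity at prostaglandin D2 receptor 2 (Homo sapiens), read by BRET and beta-arrestin recruitment; on this read-out higher numbers stand for weaker inhibition and lower numbers for stronger inhibition:

compound 1, `O=C(O)Cc1sc(C(c2ccccc2)c2ccccc2)nc1-c1ccccc1`: 370 nM
compound 2, `CCC(c1ccccc1)c1nc(-c2ccc(Cl)cc2)c(CC(=O)O)s1`: > 100000 nM, a limit of the assay
compound 3, `O=C(O)Cc1sc(C(c2ccc(F)cc2)c2ccc(F)cc2)nc1-c1ccnc(N2CCCC2)c1`: > 100000 nM, a limit of the assay

All three share the same core, which carries a carboxymethyl group and two larger groups on the ring. Compound 3 stands at the limit of this assay, not at a number, and one further value shown is also a limit. Compound 1 is the only one of the three with a measured number, and it gives 370 nM in this assay. Compound 4, `N#Cc1ccc(-c2nc(C(c3ccc(F)cc3)c3ccc(F)cc3)sc2CC(=O)O)cc1`, has not yet been measured. It differs from compound 3 in one place: 4-cyanophenyl in place of 2-(pyrrolidin-1-yl)pyridin-4-yl on an aromatic carbon. Within the data shown here, no measured pair here changes only this group, so the size of the step is open. Compound 4 is expected to gain activity in this assay, with a step of an at least 100-fold lower number from compound 3 to compound 4 (2.00 log units; beyond the scatter), because compound 1 gives 370 nM with a plain phenyl at the same position. For compound 4 the estimate is 1000 nM, within a range from 100 nM to 30000 nM.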

Compound 4, half-maximal inhibitory concentration: 1500 nM
Beside the measured number, compound 4's estimate is 1.5-fold (0.18 log units) below it; the range from low to high includes it.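

In this assay, the group on the aromatic carbon next to the ring nitrogen turns out to matter strongly: 4-cyanophenyl in place of 2-(pyrrolidin-1-yl)pyridin-4-yl gives an at least 66-fold lower number from compound 3 to compound 4 (1.82 log units; beyond the scatter). This is the first pair shown that differs in one place only, so the earlier compounds could not tie a change in activity to this position. Compound 3 sits at a limit of the assay, so the full size of the step stays unknown: the limit of > 100000 nM in this assay, at which 2 of the 4 values shown sit.

The pair does not separate the parts of the change, so the roles of the pyrrolidine ring, the pyridine ring and the nitrile remain unresolved. Also open, going by these compounds, is how groups such as 4-methoxyphenyl or 2-aminopyridin-4-yl would read at this position on the same core.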